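Fluorophenyl for ethoxycarbonyl in a series at the limit

The compounds below may be only part of what the source reports. "The series", "measured", "known", "first", "only" and "open" are said of these compounds alone.

Of the compounds shown here, two have been read in an ADME assay on BJ cells (Homo sapiens) for cytotoxicity, with a stated time of 72 h; on this read-out lower numbers stand for an effect already at smaller amounts and higher numbers for an effect only at larger amounts of compound. Compound 1 `C=C[C@@](C)(/C=C/c1ccc(O)cc1)CC/C=C(\C)CO` gives > 36600 nM, which is a limit of the assay and not a number. Compound 2 `C=C[C@@](C)(/C=C/c1ccc(O)c(/C=C/C(=O)OCC)c1)CCC=C(C)C` gives > 36600 nM, which is likewise a limit and not a number. Compound 2 therefore has no numeric position, and the record so far comes down to the limit of > 36600 nM in this assay, at which 2 of the 2 values shown sit. Among the measured compounds shown here, no measured step is available to size the next change.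

Compound 3 `C=C[C@@](C)(/C=C/c1ccc(O)c(/C=C/c2ccc(F)cc2)c1)CCC=C(C)C` is the next to be read. Its difference from compound 2 is 4-fluorophenyl in place of ethoxycarbonyl on a double-bonded chain carbon bound to a double-bonded chain carbon.

The only anchor for an expectation is compound 2 at > 36600 nM, a limit. The expected step of an at least 1.1-fold lower number from compound 2 to compound 3 (0.04 log units; that floor lies within the scatter) is small, most likely none beyond the scatter, and any shift would be expected towards smaller amounts. A further limit in place of a number is the likeliest report. In this assay compound 3 is estimated at 33000 nM, with an expected range of 12000 nM to 60000 nM.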

Compound 3, half-maximal effective concentration: > 36600 nM
Compound 3 ended at the assay's limit; the forecaster's own chance of this, stated with the estimate: 65%; middle value at least 1.1-fold (0.04 log units) from the limit.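

No step can be read from compound 2 to compound 3, since each gives only a limit of the assay and not a number, so the change from ethoxycarbonyl to 4-fluorophenyl has no readable size. The record stays at a single limit: the limit of > 36600 nM in this assay, at which 3 of the 3 values shown sit. The compounds shown leave open whether any member of the series gives a number in this assay and how far either group would move it.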